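The compounds below may be only part of what the source reports. "The series", "measured", "known", "first", "only" and "open" are said of these compounds alone.

Compound 2 `COc1cc(-c2cc(/C=C/C(=O)c3ccc(N)cc3)[nH]n2)cc(OC)c1OC` gives the higher of the two numbers measured in a functional assay on MDA-MB-231 cells (Homo sapiens) for cytotoxicity, read by sulforhodamine B assay, with a stated time of 48 h, tested at 0.1 uM (a higher number here means a weaker effect of the compound at the concentration tested, a lower number a stronger effect), namely 91%. Compound 1 `COc1ccc(-c2cc(/C=C/C(=O)c3ccc(N)cc3)[nH]n2)cc1` gives 89% in this assay, and the gap between the two lies within the scatter, so both show only a weak effect at the tested concentration. Compound 3 `COc1cc(-c2cc(/C=C/C(=O)c3ccc(Cl)c(Cl)c3)[nH]n2)cc(OC)c1OC` differs from compound 2 by 3,4-dichlorophenyl in place of 4-aminophenyl on a carbonyl carbon. Within the data shown here, no measured pair shows the size of such a change, so the expected step from compound 2 to compound 3 in this assay is small, at most a modest drop, a number 7 percentage points lower from compound 2 to compound 3 (within the scatter). Compound 3 is therefore expected to give about 84% in this assay, between 62% and 100%.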

Compound 3, a percentage reported as activity, at one concentration (the size of the read-out at that concentration, not a potency): 102%
Estimate against measurement, compound 3: 18 percentage points below, outside the stated range (above it).
By their numbers in this assay, from the lowest: compounds 1 and 2 (each within the scatter of the next); then compound 3.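

Compound 1 and compound 2 both carry 4-aminophenyl on the carbonyl carbon, so they could not show how this position responds to a change of group. Placing 3,4-dichlorophenyl there gives a number 11 percentage points higher from compound 2 to compound 3 (beyond the scatter) in this assay, a modest move towards a weaker effect from an already weak start, so the group at this position does influence the read-out. From the compounds shown here alone, whether a plain phenyl or a 4-hydroxyphenyl at this position would move the number in either direction stays open. Nothing measured here gives a reason for the shift.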